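Cyanoguanidine Benzopyrans: Swapping an Aryl Group on the Guanidine

The source may report more compounds than this note shows. Statements on the series, on what has been measured and on what is new or still open speak of the compounds shown alone.

Measured compounds:
compound 1 `CC1(C)Oc2ccc(C#N)cc2[C@@H](/N=C(\NC#N)Nc2ccc(N)cc2)[C@@H]1O` gives 3500 nM
compound 2 `C/N=C(\NC#N)N[C@@H]1c2cc(C#N)ccc2OC(C)(C)[C@H]1O` gives 200 nM

Both were tested in a functional assay (aorta) with Rattus norvegicus as the target; on this read-out lower numbers stand for stronger inhibition and higher numbers for weaker inhibition. Of the two numbers, compound 1 stands at the highest, and compound 2 sits well below it; the gap between them is beyond the scatter. Compound 3 `CC1(C)Oc2ccc(C#N)cc2[C@@H](/N=C(\NC#N)Nc2ccc(Cl)c(Cl)c2)[C@@H]1O` has not yet been measured. It differs from compound 1 in one place: 3,4-dichlorophenyl in place of 4-aminophenyl on an amine nitrogen. For the measured compounds named here, no step between measured compounds bears on this change, so the expectation rests on where compound 1 stands and on the change itself. From compound 1 to compound 3, a modest step toward a lower number is expected, a 3.5-fold lower number from compound 1 to compound 3 (0.54 log units; beyond the scatter), though a step of no more than the scatter would not surprise. Compound 3 is expected to reach about 1000 nM, with a range from 200 nM to 5000 nM.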

Compound 3, half-maximal inhibitory concentration: 4600 nM
The estimate for compound 3 lay 4.6-fold (0.66 log units) below the measured number; the measured number falls inside the stated range.
By their numbers in this assay, from the lowest: compound 2; then compounds 1 and 3 (each within the scatter of the next).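

In this assay, placing 3,4-dichlorophenyl instead of 4-aminophenyl on the amine nitrogen gives a 1.3-fold higher number from compound 1 to compound 3 (0.12 log units; within the scatter). For the compounds shown here, this is the first reading of a change between two aryl groups at this position, and the two cannot be told apart, even though 4-aminophenyl counts a hydrogen-bond donor and acceptor and 3,4-dichlorophenyl counts neither. Nothing measured here offers an explanation for this result.

The compounds shown leave open whether any other aryl group on this nitrogen, such as an unsubstituted phenyl or a pyridine ring, would separate from these two. They also leave open how a benzyl group or an ethyl chain would read at the same place on the core of compound 1.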